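Lengthening the linker and exchanging the terminal group

This account rests on a few compounds, and the source may have more. Where it says the series, first, only, none or still open, it means among the compounds named here.

Measured compounds:
- compound 1, `C/N=C(/NC#N)NCCCn1nc(-c2ccccc2)ccc1=O`: 40.5%
- compound 2, `CC/N=C(/NC#N)NCCCn1nc(-c2ccccc2)ccc1=O`: 62.9%
- compound 3, `N/C(S)=N/CCCCn1nc(-c2ccccc2)ccc1=O`: 72%

In a functional assay on the whole organism with Rattus norvegicus as the target, at a dose of 100 mg/kg (a higher number here means more inhibition at the dose given (going by the name of the read-out), a lower number less inhibition), compound 3 gives the highest of the three numbers. Its nearest neighbour is compound 2, and a number 9.1 percentage points higher from compound 2 to compound 3 (within the scatter), so these two cannot be told apart. Compound 1 lies clearly lower, since a number 31.5 percentage points higher from compound 1 to compound 3 (beyond the scatter); a smaller change within that pair, a number 22.4 percentage points higher from compound 1 to compound 2 (beyond the scatter), also moved the number upward.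

Compound 4, `N#CNC(=N)NCCCCn1nc(-c2ccccc2)ccc1=O`, has not yet been measured. It differs from compound 3 in one place: a group of 6 heavy atoms (2 carbon, 4 nitrogen; no ring) in place of a group of 4 heavy atoms (1 carbon, 2 nitrogen, 1 sulfur; no ring), on a saturated chain carbon, four bonds along the chain from an aromatic nitrogen. The steps measured so far point in the opposite direction, because a number 31.5 percentage points higher from compound 1 to compound 3 (beyond the scatter) was large when a nitrogen-rich group of this kind gave way to the sulfur-bearing one on a shorter chain, while a number 9.1 percentage points higher from compound 2 to compound 3 (within the scatter) stayed within the scatter. Reversing that kind of exchange, now on the longer chain, is expected to lower the number modestly, with a number 22 percentage points lower from compound 3 to compound 4 (beyond the scatter). Compound 4 is therefore estimated to give 50%, within a range of 30% to 70%.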

Compound 4, a percentage reported as inhibition, in the whole organism at one dose (the size of the read-out at that dose, not a potency): 61.2%
Estimate against measurement, compound 4: 11.2 percentage points below; low and high end bracket the measured number.
By their numbers in this assay, from the lowest: compound 1; then compounds 4, 2 and 3 (each within the scatter of the next, the first and the last beyond it).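

In this assay, the direct exchange at this place, on a saturated chain carbon four bonds along the chain from an aromatic nitrogen, gives a number 10.8 percentage points lower from compound 3 to compound 4 (beyond the scatter) when the group of 6 heavy atoms replaces the sulfur-bearing group of 4 heavy atoms, so the two groups can be separated on the same chain. The nitrogen-rich group does not tie this read-out to the low end, since the steps of a number 1.7 percentage points lower from compound 2 to compound 4 (within the scatter) and a number 20.7 percentage points higher from compound 1 to compound 4 (beyond the scatter) place compound 4 level with compound 2 and clear of compound 1. Nothing available explains these differences.

The compounds shown leave open whether an amine or a carboxylic acid at the same place would give a number closer to compound 3 or to compound 4. They also leave open how a longer chain carrying the sulfur-bearing group would behave.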